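Chloro for Methyl on the Phenoxy Ring

The source may report more compounds than this note shows. Statements on the series, on what has been measured and on what is new or still open speak of the compounds shown alone.

Compound 1 `Cc1ccccc1Oc1ccc(N2CCC[C@H]2CC(=O)O)cc1`: 5600 nM
Compound 2 `Cc1cccc(Oc2ccc(N3CCC[C@H]3CC(=O)O)cc2)c1`: 2400 nM

In a functional assay on cells for agonist activity at Free fatty acid receptor 1 (Mus musculus), read by FLIPR and calcium flux, with a stated time of 100 s (a higher number here means that more compound is needed for the effect, a lower number that less compound is needed), compound 2 gives 2400 nM, the lowest of the two numbers measured. Its nearest neighbour is compound 1, which gives 5600 nM. Among the compounds with values here, the only measured step, a 2.3-fold lower number from compound 1 to compound 2 (0.37 log units; beyond the scatter), moves the methyl from one position of the phenoxy ring to another; it does not exchange the methyl for a different group, so it offers no direct guide to what follows.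

Compound 3 `O=C(O)C[C@@H]1CCCN1c1ccc(Oc2cccc(Cl)c2)cc1` differs from compound 2 by chloro in place of methyl on an aromatic carbon. Within the data shown here, no measured step in this assay bears on this kind of exchange. The expectation rests on compound 2 and its 2400 nM alone. The expected step is a 1.2-fold lower number from compound 2 to compound 3 (0.08 log units; within the scatter), which is not expected to exceed the scatter. Compound 3 is therefore estimated at 2000 nM, within a range from 700 nM to 6000 nM.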

Compound 3, half-maximal effective concentration: > 16000 nM
Compound 3: only a limit was reported; the forecaster's own chance of this, stated with the estimate: 5%; middle value at least 8.0-fold (0.90 log units) from the limit.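

At this aromatic carbon, meta to a large group, two groups of one heavy atom each are far from interchangeable: chloro in place of methyl gives an at least 6.6-fold higher number from compound 2 to compound 3 (0.82 log units; beyond the scatter). Compound 3 has only a limit of the assay, not a number: the limit of > 16000 nM in this assay, at which 1 of the 3 values shown sits. The 3-chlorophenyl group also compares poorly with the 2-methylphenyl group, with an at least 2.8-fold higher number from compound 1 to compound 3 (0.45 log units; beyond the scatter), so compound 3 sits on the high side of both earlier compounds, and the methyl at this place in compound 2 cannot be swapped for chloro without a clear cost.

The compounds shown leave open whether this loss is particular to chloro or would also follow other groups at the same place, such as fluoro, methoxy or an amine. From the compounds shown here alone, with only a limit for compound 3, the full size of both steps also remains unknown.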